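A few compounds are considered here, and "the series" means these few. Any claim that something is new, unique, unknown or untested is made for them only; others in the source may bear on it.

Compound 1 `COc1ccc(OC)c(NC(=O)Nc2nn(-c3ccccc3)c(=O)c3ccccc23)c1` gives the lowest number of the three measured compounds in an assay on CHO cells for displacement of a labelled ligand from adenosine receptor A3 (Homo sapiens) (a lower number here means a stronger inhibitor, a higher number a weaker inhibitor), with 0.776 nM. Compound 3 `COc1ccccc1NC(=O)Nc1nn(-c2ccccc2)c(=O)c2ccccc12` gives 8.9 nM and compound 2 `COc1ccc(NC(=O)Nc2nn(-c3ccccc3)c(=O)c3ccccc23)cc1` gives 60.6 nM in this assay. The step to compound 4 `COc1ccccc1CNC(=O)Nc1nn(-c2ccccc2)c(=O)c2ccccc12` is 2-methoxybenzyl in place of 2,5-dimethoxyphenyl on an amide-type nitrogen. Among the compounds with values here, two measured steps bear on it: an 11-fold higher number from compound 1 to compound 3 (1.06 log units; beyond the scatter) shows what removing one methoxy alone costs, and a 78-fold higher number from compound 1 to compound 2 (1.89 log units; beyond the scatter) shows how far the number can climb when the aryl substitution pattern changes. Inserting a methylene between the ring and the urea nitrogen has no measured counterpart here. Compound 4 is therefore expected to give a weaker result than compound 1, with a step of about a 64-fold higher number from compound 1 to compound 4 (1.81 log units; beyond the scatter) in this assay, estimated at 50 nM with a range from 8 nM to 400 nM.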

Compound 4, inhibition constant: 274 nM
The estimate for compound 4 lay 5.5-fold (0.74 log units) below the measured number, and the stated range covers the measured number.
By their numbers in this assay, from the lowest: compound 1; then compound 3; then compound 2; then compound 4.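

In this assay, the step of a 31-fold higher number from compound 3 to compound 4 (1.49 log units; beyond the scatter) keeps the methoxy-bearing ring and changes only the link to the amide-type nitrogen, so it shows that 2-methoxybenzyl costs far more here than 2-methoxyphenyl. This change also outweighs moving the methoxy group, as the step of a 4.5-fold higher number from compound 2 to compound 4 (0.66 log units; beyond the scatter) leaves compound 4 with the highest number of the four, and the full step of a 350-fold higher number from compound 1 to compound 4 (2.55 log units; beyond the scatter) is the largest in the series. Nothing available explains why the number rises. Still open, on these data alone, is whether 2,5-dimethoxybenzyl would recover any of the loss, or how a longer chain on this nitrogen would behave.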